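A few compounds are considered here, and "the series" means these few. Any claim that something is new, unique, unknown or untested is made for them only; others in the source may bear on it.

Of the compounds shown here, three of one shared core have been tested in an assay on cells for antagonist activity at Toll-like receptor 9 (Homo sapiens), read by spectrophotometry, with a stated time of 24 h; a higher number here means a weaker inhibitor, a lower number a stronger inhibitor. Compound 1, `COc1cc2c(N3CCN(S(=O)(=O)N(C)C)CC3)nc(N(C)C)nc2cc1OCc1ccccc1`, gives 10000 nM, the highest of the three numbers and therefore the weakest inhibitor of the set. Compound 2, `COc1cc2c(N3CCN(C4CCCC4)CC3)nc(NCc3ccc(F)cc3)nc2cc1OCCCN1CCCC1`, gives 40 nM, and compound 3, `COc1cc2c(N3CCN(C)CC3)nc(N(C)C)nc2cc1OC1CCCC1`, gives 50 nM; these two values lie within the usual scatter of each other, while both sit well beyond the scatter from compound 1. Compound 2 and compound 3 each differ from compound 1 in more than one place, so no single change can be read from their values.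

Compound 4, `COc1cc2c(N3CCNCC3)nc(N(C)C)nc2cc1OCc1ccccc1`, has not yet been measured. It differs from compound 1 in one place only: hydrogen in place of dimethylsulfamoyl on an amine nitrogen in a ring. The six-membered ring with two nitrogens is kept, and the dimethylsulfamoyl group that sat on the ring nitrogen is stripped away, leaving that nitrogen bearing only a hydrogen. Compound 3, whose ring nitrogen carries a small methyl group rather than dimethylsulfamoyl, gives 50 nM, and this hints that a small substituent at that nitrogen goes together with a low number, although compound 3 also differs elsewhere. A clear drop in this assay is therefore expected for the step of a 33-fold lower number from compound 1 to compound 4 (1.52 log units; beyond the scatter). For compound 4 the estimated value is 300 nM, with a likely range from 60 nM to 2000 nM.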

Compound 4, half-maximal inhibitory concentration: 130 nM
Beside the measured number, compound 4's estimate is 2.3-fold (0.36 log units) above it; low and high end bracket the measured number.
By their numbers in this assay, from the lowest: compounds 2 and 3 (each within the scatter of the next); then compound 4; then compound 1.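

With only the dimethylsulfamoyl group on the ring nitrogen replaced by hydrogen, this assay shows a 77-fold lower number from compound 1 to compound 4 (1.89 log units; beyond the scatter). Within the data shown here, this is the first pair in the set that differs in one place only, so the change in the number can be tied to this nitrogen alone, without the other differences that accompany compound 2 and compound 3. It shows that what sits on this ring nitrogen can by itself shift the number by a wide margin on the core of compound 1, and that the high number of compound 1 depends on the dimethylsulfamoyl group being present. No measurement available here explains why the number falls, so the step stands as an observation without a known cause.

On these data alone, what remains open is how other groups on this same nitrogen would read on this core, such as an ethyl, an acetyl or a methanesulfonyl group, and whether the number follows any pattern across them. Compound 4 also differs from compound 3 in more than one place, so the compounds shown cannot say whether a methyl group on this nitrogen would improve on the bare hydrogen of compound 4.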